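Hydrazone series: cyclopropyl in place of butyl

The source may report more compounds than this note shows. Statements on the series, on what has been measured and on what is new or still open speak of the compounds shown alone.

Measured compounds:
compound 1 `CCC/C(C)=N\Nc1nc(-c2cccc([N+](=O)[O-])c2)cs1` 38000 nM
compound 2 `CCCC/C(C)=N\Nc1nc(-c2cccc([N+](=O)[O-])c2)cs1` 6330 nM

In an assay on isolated protein for inhibition of Amine oxidase [flavin-containing] A (Homo sapiens), read by fluorescence, with a stated time of 20 min (a lower number here means a stronger inhibitor, a higher number a weaker inhibitor), compound 2 stands lowest of the two numbers; its nearest neighbour is compound 1, and the step of a 6.0-fold lower number from compound 1 to compound 2 (0.78 log units; beyond the scatter) lies beyond the scatter. Compound 3 `C/C(=N/Nc1nc(-c2cccc([N+](=O)[O-])c2)cs1)C1CC1` is not yet measured. The change is cyclopropyl in place of butyl on a carbon with a double bond to nitrogen. Among the compounds with values here, the single measured step bears on it only indirectly: lengthening the chain from compound 1 to compound 2 lowered the number, and compound 3 carries a smaller group again. A step back towards the number of compound 1 is therefore expected, a 2.8-fold higher number from compound 2 to compound 3 (0.45 log units; beyond the scatter), though the ring leaves this uncertain. Compound 3 is estimated at 18000 nM, within 5000 nM to 60000 nM.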

Compound 3, half-maximal inhibitory concentration: 2660 nM
Compound 3: middle estimate off by 6.8-fold (0.83 log units), on the high side; measured number below the stated range.
By their numbers in this assay, from the lowest: compound 3; then compound 2; then compound 1.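

In this assay, the count of heavy atoms does not set the order at this carbon: cyclopropyl in place of butyl gives a 2.4-fold lower number from compound 2 to compound 3 (0.38 log units; beyond the scatter), although the group entering is the smaller one. Against propyl the ring gives a 14-fold lower number from compound 1 to compound 3 (1.15 log units; beyond the scatter), so compound 3 goes against the fall seen with the longer chain in compound 2. Nothing available accounts for this order.

Open, going by these compounds, is whether cyclobutyl or isopropyl on this carbon would fall with compound 3 or with the open chains. Also open, on these data alone, is whether the cyclopropyl step persists when an amine replaces the nitro group.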